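The source may report more compounds than this note shows. Statements on the series, on what has been measured and on what is new or still open speak of the compounds shown alone.

Compound 1 `c1cn2cc(-c3ccsc3)nc(-c3ccc4ncn(C5CCCCC5)c4c3)c2n1` gives 15.4% in a functional assay on KM12 cells (Homo sapiens) for inhibition, read by sulforhodamine B assay, with a stated time of 48 h, tested at 10 uM; a higher number here means more inhibition at the concentration tested (going by the name of the read-out), a lower number less inhibition.
Compound 2 `Brc1ccc(-c2cn3ccnc3c(-c3ccc4ncn(C5CCCCC5)c4c3)n2)cc1` gives 23.3% in this assay.
Compound 3 `COc1ccccc1-c1cn2ccnc2c(-c2ccc3ncn(C4CCCCC4)c3c2)n1` gives 3.58% in this assay.

Among these three numbers compound 1 stands second highest. Its nearest neighbour is compound 2, reached by a number 7.9 percentage points higher from compound 1 to compound 2 (within the scatter); the furthest is compound 3, reached by a number 11.8 percentage points lower from compound 1 to compound 3 (beyond the scatter). Between compound 2 and compound 3 lies a number 19.7 percentage points lower from compound 2 to compound 3 (beyond the scatter).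

Compound 4 `c1csc(-c2cn3ccnc3c(-c3ccc4ncn(C5CCCCC5)c4c3)n2)c1` has not yet been measured in this assay. It differs from compound 1 only as thiophen-2-yl in place of thiophen-3-yl on an aromatic carbon. Going by the values given here, none of the measured steps swaps one thiophenyl for another; both steps from compound 1 exchange thiophen-3-yl for a six-membered aryl, and one lies within the scatter while the other is modest. A shift of the sulfur within the same five-membered ring is a smaller change than either, so no step beyond the scatter is expected in this assay, in either direction. Compound 4 is therefore estimated at 15%, within 3% to 28%, which is expected to mean a number 0.4 percentage points lower from compound 1 to compound 4 (within the scatter).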

Compound 4, a percentage reported as inhibition, at one concentration (the size of the read-out at that concentration, not a potency): 4.89%
For compound 4 the middle estimate is 10.1 percentage points above the measured one; the measured number falls inside the stated range.
By their numbers in this assay, from the lowest: compounds 3 and 4 (each within the scatter of the next); then compounds 1 and 2 (each within the scatter of the next).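

At this position in this assay, the same atoms joined differently are enough to shift the read-out: with thiophen-2-yl in place of thiophen-3-yl, the result is a number 10.5 percentage points lower from compound 1 to compound 4 (beyond the scatter), so the two thiophenyl groups are not interchangeable here. The thiophen-2-yl group falls level with 2-methoxyphenyl, a number 1.3 percentage points higher from compound 3 to compound 4 (within the scatter), and apart from 4-bromophenyl, a number 18.4 percentage points lower from compound 2 to compound 4 (beyond the scatter). Nothing available here explains why the two thiophenyl groups differ.

The compounds shown leave open whether a furanyl or pyridinyl group at this position, or an amine on the phenyl ring, would stand with thiophen-3-yl or with thiophen-2-yl. They also leave open whether the substituent itself or its place on the phenyl ring separates compound 2 from compound 3, since the two differ in both.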